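The source may report more compounds than this note shows. Statements on the series, on what has been measured and on what is new or still open speak of the compounds shown alone.

In an ADME assay on MT4 cells (Homo sapiens) for cytotoxicity, read by MTT assay, with a stated time of 5 days (on this read-out higher numbers stand for lower toxicity in this test and lower numbers for higher toxicity in this test), compound 2 `O=C(CSc1snnc1-c1ccc(Br)cc1Br)Nc1ccccc1Cl` stands only at a limit of the read-out. In this assay compound 2 gives > 240000 nM, which is a limit. In this assay compound 1 `O=C(CSc1snnc1-c1ccc(Br)cc1Br)Nc1ccccc1F` gives >= 27800 nM, also a limit. The step that the two limits leave unreadable from compound 1 to compound 2 is therefore of unreadable size. Compound 3 `O=C(CSc1snnc1-c1ccc(Br)cc1Br)Nc1nccs1` differs from compound 2 by 1,3-thiazol-2-yl in place of 2-chlorophenyl on an amide-type nitrogen. Within the data shown here, no measured step bears on this change, so no size can be drawn from the series. The expected step is estimated as an at least 1.6-fold lower number from compound 2 to compound 3 (0.20 log units; that floor lies within the scatter), no more than the scatter. In this assay compound 3 is expected at 150000 nM, with a range from 30000 nM to 300000 nM.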

Compound 3, half-maximal cytotoxic concentration: 87800 nM
Beside the measured number, compound 3's estimate is 1.7-fold (0.23 log units) above it; measured number inside the range.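

In this assay, the amide-type nitrogen gives its first readable change: 1,3-thiazol-2-yl in place of 2-chlorophenyl gives an at least 2.7-fold lower number from compound 2 to compound 3 (0.43 log units; beyond the scatter). Compound 2 stands at a limit, so that step is only a floor: the limit of > 240000 nM in this assay, at which 1 of the 3 values shown sits. Compound 1 also stands at a limit, and the steps involving it cannot be read: the limit of >= 27800 nM in this assay, at which 1 of the 3 values shown sits.

Open, from the compounds shown here alone, is whether the lower number goes with the hetero atoms of the 1,3-thiazol-2-yl ring or simply with the departure of 2-chlorophenyl. A pyridine ring, a simple alkyl chain or a carboxylic acid on that nitrogen would help separate the two.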